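The source may report more compounds than this note shows. Statements on the series, on what has been measured and on what is new or still open speak of the compounds shown alone.

Measured in a functional assay on the whole organism (strain albino) for inhibition, with Rattus norvegicus as the target, read by paw edema, with stated times of 30 min and 1 h, at a dose of 0.28 mmol/kg by the oral route; on this read-out higher numbers stand for more inhibition at the one dose given (going by the name of the read-out) and lower numbers for less inhibition:

- compound 1, `COc1ccc(-c2nnc(SCC(=O)Nc3ccc(/C(C)=N/O)cc3)n2-c2ccccc2)cc1`: 45%
- compound 2, `C=CCn1c(SCC(=O)Nc2ccc(/C(C)=N/O)cc2)nnc1-c1ccc(OC)cc1`: 54%
- compound 3, `COc1cc(-c2nnc(SCC(=O)Nc3ccc(C(C)=O)cc3)n2-c2ccccc2)cc(OC)c1OC`: 49%

Compound 1 and compound 2 share a core and differ in one place: allyl in place of phenyl on an aromatic nitrogen. In this assay this gave a number 9 percentage points higher from compound 1 to compound 2 (within the scatter), a step within the usual scatter of repeated measurements.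

Compound 3 carries a different core, and the difference between the two cores is not broken down here. In this assay compound 3 gives 49%, which is within the scatter of the value of compound 1 and within the scatter of the value of compound 2, so the three measured values cannot be ordered against each other.

Compound 4, `C=CCn1c(SCC(=O)Nc2ccc(C(C)=O)cc2)nnc1-c1cc(OC)c(OC)c(OC)c1`, is not yet measured. It stands to compound 3 as compound 2 stands to compound 1: allyl in place of phenyl on an aromatic nitrogen. This is the same kind of change, not the same one, since around the place the ring atom bears a 3,4,5-trimethoxyphenyl group in compound 3 where it bears a 4-methoxyphenyl group in compound 1. Going by the values given here, the expectation for compound 4 rests on the single precedent and is therefore uncertain. The step from compound 3 to compound 4 in this assay is estimated as a number 6 percentage points higher from compound 3 to compound 4 (within the scatter) because a number 9 percentage points higher from compound 1 to compound 2 (within the scatter) was a step within the scatter. Compound 4 is expected to give 55% in this assay, with a range from 42% to 66%.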

Compound 4, a percentage reported as inhibition, in the whole organism at one dose (the size of the read-out at that dose, not a potency): 48%
For compound 4 the middle estimate is 7 percentage points above the measured one, and the stated range covers the measured number.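

In this assay, allyl in place of phenyl on an aromatic nitrogen, here on the core that bears the 3,4,5-trimethoxyphenyl group, gives a number 1 percentage points lower from compound 3 to compound 4 (within the scatter). Set beside the same change on the core of compound 1, the two steps do not differ beyond what repeated measurement would give: the same change on two cores in this assay, a number 9 percentage points higher (within the scatter) from compound 1 to compound 2 and a number 1 percentage points lower (within the scatter) from compound 3 to compound 4, 10 percentage points apart, within the scatter of two such steps. This shows no dependence of the change on the core, but it does not show that the step carries over from one core to the other: neither step stands clear of the scatter, so the change has no demonstrated effect on either core, and two pairs cannot exclude a core dependence smaller than the scatter.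

The compounds shown leave open whether any other group on that aromatic nitrogen, such as a methyl group, a benzyl group or a longer chain, would give a step beyond the scatter on either core. Also open, from the compounds shown here alone, is whether a group of another kind on the far phenyl ring, such as an amine or a carboxylic acid, would move the read-out, and how these compounds would compare at doses other than the single one used here.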